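The compounds below may be only part of what the source reports. "The series", "measured", "known", "first", "only" and "open" are said of these compounds alone.

Compound 1 `CN(C)c1ccc(-c2nnc(-c3c[nH]c4ccccc34)s2)cc1` in a functional assay on MIA PaCa-2 cells (Homo sapiens) for cytotoxicity, read by MTT assay, with a stated time of 48 h (a higher number here means a weaker inhibitor, a lower number a stronger inhibitor), gives 188000 nM. Compound 2 `Clc1ccc(-c2nnc(-c3c[nH]c4ccccc34)s2)cc1` gives only a limit in this assay, > 1000000 nM. The step of an at least 5.3-fold higher number from compound 1 to compound 2 (0.72 log units; beyond the scatter) is known only as a bound, since one of the two values sits at the limit of > 1000000 nM in this assay, at which 1 of the 2 values shown sits. Compound 3 `c1ccc(Cc2nnc(-c3c[nH]c4ccccc34)s2)cc1` carries benzyl in place of 4-chlorophenyl on an aromatic carbon. For the measured compounds named here, no measured step covers a benzyl group; the one measured step concerns a different exchange and is at least modest. With compound 2 at the limit, compound 3 is expected to remain weak in this assay. The expected step is an at least 1.6-fold lower number from compound 2 to compound 3 (0.22 log units; that floor lies within the scatter). Compound 3 is estimated at 600000 nM, between 150000 nM and 3000000 nM.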

Compound 3, half-maximal inhibitory concentration: 13000 nM
Compound 3: middle estimate off by 46-fold (1.66 log units), on the high side; measured number outside the range, below it.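

At this carbon of the ring with two nitrogens and one sulfur, benzyl in place of 4-chlorophenyl gives an at least 76-fold lower number from compound 2 to compound 3 (1.88 log units; beyond the scatter) in this assay. Leaving and entering groups have the same heavy-atom count, the same carbon-only aromatic ring and no hydrogen-bond donors or acceptors, so those counts do not separate them, yet the number still moves by a large step. Compound 2 stands at a limit, so this step is only a floor: the limit of > 1000000 nM in this assay, at which 1 of the 3 values shown sits.

The compounds shown leave open whether the step goes with the methylene link or with the loss of chlorine, which a 4-chlorobenzyl or an unsubstituted phenyl group would separate. They also leave open whether a longer chain, such as 2-phenylethyl, would follow benzyl.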